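Bromo to Chloro on the Thiophene of a Bicyclic Amine

The source may report more compounds than this note shows. Statements on the series, on what has been measured and on what is new or still open speak of the compounds shown alone.

Going by the values given here, the three compounds measured so far share one bicyclic amine core and differ only in the substituent on the thiophene ring. Compound 1 `CSc1ccc(CN[C@@H]2C[C@H]3C[C@@H]([C@H]2C)C3(C)C)s1` carries a methylsulfanyl group, compound 2 `C[C@H]1[C@H](NCc2ccc(Br)s2)C[C@H]2C[C@@H]1C2(C)C` a bromo group, and compound 3 `C[C@H]1[C@H](NCc2sccc2C2CC2)C[C@H]2C[C@@H]1C2(C)C` a cyclopropyl group. In an ADME assay on MDCK cells (Canis lupus familiaris) for cytotoxicity, read by microscopy, with a stated time of 48 h (on this read-out higher numbers stand for lower toxicity in this test and lower numbers for higher toxicity in this test), compound 1 gives 25000 nM, compound 2 gives 43000 nM, and compound 3 gives 25000 nM. Compound 2 thus sits at the top of the numbers shown, but its gaps to compound 1 and to compound 3 both fall within the scatter, so the three compounds are not separated by this test.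

Among the compounds with values here, the only measured step that changes the same position is a 1.7-fold higher number from compound 1 to compound 2 (0.24 log units; within the scatter); it left the read-out where it was. Compound 4 `C[C@H]1[C@H](NCc2ccc(Cl)s2)C[C@H]2C[C@@H]1C2(C)C` continues at this position with chloro in place of bromo on an aromatic carbon. Within the data shown here, no measured pair shows a swap of one halogen for another, so the expectation rests on compound 2 with 43000 nM and on the flat step from compound 1 to compound 2 alone. On that basis the step of a 1.2-fold lower number from compound 2 to compound 4 (0.09 log units; within the scatter) is expected to stay within the scatter. Compound 4 is therefore estimated to give about 35000 nM, with a range from 17000 nM to 70000 nM.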

Compound 4, minimum cytotoxic concentration: 25000 nM
The estimate for compound 4 lay 1.4-fold (0.15 log units) above the measured number; measured number inside the range.
By their numbers in this assay, from the lowest: compounds 1, 3, 4 and 2 (each within the scatter of the next).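

Going by these compounds alone, the first exchange of one halogen for another at this position, 5-bromothiophen-2-yl to 5-chlorothiophen-2-yl, gives in this assay a 1.7-fold lower number from compound 2 to compound 4 (0.24 log units; within the scatter) and so does not separate the two halogens. Chloro in place of methylsulfanyl on the same aromatic carbon gives no change at the digits printed from compound 1 to compound 4 (within the scatter) and adds a second comparison with that group, so methylsulfanyl, bromo and chloro at this position are not told apart by this test across compounds 1, 2 and 4. Nothing available offers an explanation for this flat result.

What the compounds shown leave open is whether any group at this position can move the read-out beyond the scatter, since a carboxylic acid, an amine or a longer chain on this aromatic carbon would differ from the three groups compared here far more than they differ from one another. Within the data shown here, it also remains open whether fluoro or iodo would fit with bromo and chloro, as the only halogen comparison so far rests on a single pair.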